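A few compounds are considered here, and "the series" means these few. Any claim that something is new, unique, unknown or untested is made for them only; others in the source may bear on it.

The measured compounds in a functional assay on SK-BR-3 cells (Homo sapiens) for antiproliferative activity, read by XTT assay, with a stated time of 72 h; a lower number here means a stronger inhibitor, a higher number a weaker inhibitor:
compound 1 `COc1ccc(-c2cc3ccccc3nc2/C=C/C(=O)c2ccc(O)cc2)cc1` gives 3880 nM;
compound 2 `COc1ccc(-c2cc3ccccc3nc2/C=C/C(=O)c2c(OC)cccc2OC)cc1` gives 3830 nM;
compound 3 `COc1ccc(-c2cc3ccccc3nc2/C=C/C(=O)c2ccc(OC)c(OC)c2)cc1` gives 3260 nM.

Of these three numbers compound 1 has the highest, but neither neighbour is separated from it beyond the scatter: the nearest is compound 2, at a 1.0-fold lower number from compound 1 to compound 2 (0.01 log units; within the scatter), and the furthest is compound 3, at a 1.2-fold lower number from compound 1 to compound 3 (0.08 log units; within the scatter). The remaining pair behaves the same way, with a 1.2-fold lower number from compound 2 to compound 3 (0.07 log units; within the scatter). Every one of these changes sits on the aryl ring attached to the carbonyl carbon, and none of them shifted this assay beyond its repeat-to-repeat spread.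

Compound 4 `COc1ccc(-c2cc3ccccc3nc2/C=C/C(=O)c2ccc([N+](=O)[O-])cc2)cc1` differs from compound 1 in that same region: nitro in place of hydroxy on an aromatic carbon. Among the measured compounds shown here, no measured pair carries a nitro group, so the three steps bear on this change only by analogy, in that exchanging one oxygen pattern on that ring for another left this assay flat. On that basis no step beyond the scatter is expected in either direction.

Compound 4 is therefore estimated at 3500 nM in this assay, expected to fall between 1500 nM and 8000 nM. The step this expectation implies, a 1.1-fold lower number from compound 1 to compound 4 (0.04 log units; within the scatter), is within the scatter.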

Compound 4, half-maximal inhibitory concentration: 590 nM
Compound 4: middle estimate off by 5.9-fold (0.77 log units), on the high side; measured number below the stated range.
By their numbers in this assay, from the lowest: compound 4; then compounds 3, 2 and 1 (each within the scatter of the next).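

In this assay the aryl ring on the carbonyl carbon, which had looked indifferent to substitution, turns out to respond: nitro in place of hydroxy gives a 6.6-fold lower number from compound 1 to compound 4 (0.82 log units; beyond the scatter), and the 4-nitrophenyl ring also stands clear of the two dimethoxyphenyl rings, with a 5.5-fold lower number from compound 3 to compound 4 (0.74 log units; beyond the scatter) and a 6.5-fold lower number from compound 2 to compound 4 (0.81 log units; beyond the scatter). The flat picture therefore held only for the hydroxy and methoxy patterns of compound 1, compound 2 and compound 3, whereas the nitro group, on the same aromatic carbon para to a large group, moves the number beyond the scatter towards a stronger inhibitor. Nothing available here accounts for why the nitro group departs from the oxygen-bearing patterns.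

As far as these compounds go, it remains open whether this gain is particular to the nitro group or would also appear with another group at that place, such as a nitrile, an amine or a carboxylic acid. Also open, from the compounds shown here alone, is whether a nitro group elsewhere on that ring would give a similar step, as compound 4 carries it at only one place.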